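The source may hold more compounds than are shown below. What is called first, only, known or untested is meant among the compounds shown, and "the series" means these compounds.

The shared core of this small set carries a phenyl-substituted isoxazole-type aromatic ring system joined to a methoxy-bearing benzene ring, and the compounds differ only in the chain attached through an oxygen on that benzene ring. Compound 1 `CCN(CC)CCCOc1cc(OC)ccc1-c1cc(-c2ccccc2)no1` and compound 2 `CCCCN(C)CCCOc1cc(OC)ccc1-c1cc(-c2ccccc2)no1` both carry an amine at the end of a three-carbon chain. In a functional assay on the whole organism (blood, strain Sprague-Dawley albino) with Rattus norvegicus as the target, with stated times of 30 min and 24 h, at a dose of 100 mg/kg by the oral route (a lower number here means less inhibition, a higher number more inhibition at the dose given (going by the name of the read-out)), compound 1 gives 9.2%, and compound 2 gives 14.2%; the step of a number 5 percentage points higher from compound 1 to compound 2 (within the scatter) shows that exchanging one amine for another at that position changes little. Compound 3 `CCOC(=O)COc1cc(OC)ccc1-c1cc(-c2ccccc2)no1` instead carries an ethoxycarbonyl on the chain carbon, and for compound 3 the entry in this assay reads "not determined" (no result reported), so it stands without a number.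

Compound 4 `CCN(CC)CC(O)COc1cc(OC)ccc1-c1cc(-c2ccccc2)no1` arises from compound 3 by the change (2-(diethylamino)-1-hydroxyethyl in place of ethoxycarbonyl on a saturated chain carbon bound to an oxygen on an aromatic ring). Among the measured compounds shown here, no measured step covers this exchange directly, and the only measured step, between compound 1 and compound 2, concerns a different position and lies within the scatter. Compound 4 does, however, resemble compound 1 closely, differing from it only by the added hydroxyl on the chain. On that basis compound 4 is expected to give about 12% in this assay, most likely between 0% and 30%.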

Compound 4, a percentage reported as inhibition, in the whole organism at one dose (the size of the read-out at that dose, not a potency): 11.4%
Beside the measured number, compound 4's estimate is 0.6 percentage points above it; low and high end bracket the measured number.
By their numbers in this assay, from the lowest: compounds 1, 4 and 2 (each within the scatter of the next).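

The hydroxyl on the chain is the new feature here, and in this assay hydroxy in place of hydrogen on a saturated chain carbon bound to two saturated chain carbons gives a number 2.2 percentage points higher from compound 1 to compound 4 (within the scatter), so this added group leaves the read-out within the usual scatter. The wider exchange, 2-(diethylamino)-1-hydroxyethyl in place of 2-(butyl(methyl)amino)ethyl, gives a number 2.8 percentage points lower from compound 2 to compound 4 (within the scatter), which shows that changing the amine and adding the hydroxyl together also produces no difference that can be told from the scatter at this single dose. No measurement offered here explains why these changes make so little difference.

Compound 3 reads "not determined" (no result reported), so the ethoxycarbonyl cannot be set against the amine-bearing chains, and the compounds shown leave open how a carboxylic acid at that place would compare. Also open, from the compounds shown here alone, is whether a ring amine such as morpholine or piperidine, or a longer chain between the oxygen and the amine, would give a number that stands beyond the scatter from those of these three compounds.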